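Amide replacement and cell toxicity across the series

The source may report more compounds than this note shows. Statements on the series, on what has been measured and on what is new or still open speak of the compounds shown alone.

Measured so far:
- compound 1 `COc1ccc(-c2cnc(NC(=O)c3ccccc3O)n2C)cc1`: > 100000 nM
- compound 2 `COc1ccc(-c2cnc(NC(=O)c3cccc([N+](=O)[O-])c3)n2C)cc1`: > 100000 nM

In a toxicity assay on THP-1 cells (Homo sapiens) for inhibition (on this read-out lower numbers stand for higher toxicity in this test and higher numbers for lower toxicity in this test), compound 1 gives > 100000 nM, which is a limit of the assay and not a number. In this assay compound 2 gives > 100000 nM, again a limit and not a number. Compound 1 therefore stands at the limit of > 100000 nM in this assay, at which 2 of the 2 values shown sit. Within the data shown here, no step between measured compounds that differ in one place is available here, so no measured step size is known for this read-out.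

Compound 3 `COc1ccc(-c2cnc(NC(=O)c3ccno3)n2C)cc1` has not yet been measured in this assay. It differs from compound 1 by 1,2-oxazol-5-yl in place of 2-hydroxyphenyl on a carbonyl carbon, the change sitting on the carbonyl carbon whose other neighbour is the amide-type nitrogen. With both measured compounds resting at the limit, the step in this assay is expected to be none beyond the scatter, a step that the limit leaves unreadable from compound 1 to compound 3. For compound 3 the estimate in this assay is 150000 nM, with a range from 40000 nM to 500000 nM, and it is expected that the assay will most likely again report only a limit.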

Compound 3, half-maximal cytotoxic concentration: > 100000 nM
Compound 3: a limit, no number (the forecaster's own chance of this, stated with the estimate: 80%); the middle value does not contradict the limit.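

In this assay no step can be read between compound 1 and compound 3, because both values are limits and not numbers: the limit of > 100000 nM in this assay, at which 3 of the 3 values shown sit.

The compounds shown leave open what number any of them would reach in this assay, and whether a change of group on the carbonyl carbon shifts that read-out at all.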